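Secondary amine in place of tertiary on a fused core

A few compounds are considered here, and "the series" means these few. Any claim that something is new, unique, unknown or untested is made for them only; others in the source may bear on it.

Of the compounds shown here, three have been measured in an in vitro assay on 293-EBNA cells for binding affinity to corticotropin-releasing factor receptor 1 (Homo sapiens); a higher number here means a weaker inhibitor, a lower number a stronger inhibitor. Compound 1 `CCCCN(CC)c1nc(C)nc2c1nnn2-c1c(C)cc(C)nc1C` gives 65 nM. Compound 2 `CCC(CO)Nc1nc(C)nc2c1nnn2-c1ccc(C(C)C)cc1Br` gives 25.3 nM. Compound 3 `CCCCN(CC)c1nc(C)nc2c1ncn2-c1ccc(C(C)C)cc1Br` gives 4.3 nM, the lowest of the three numbers; the gap to compound 2 and the larger gap to compound 1 both lie beyond the usual scatter of this assay, so compound 3 is the strongest inhibitor of the three.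

Compound 4 `CCCC(CC)Nc1nc(C)nc2c1ncn2-c1ccc(C(C)C)cc1Br` keeps the core and the aryl group of compound 3 and changes only the amine: (1-ethylbutyl)amino in place of butyl(ethyl)amino on an aromatic carbon. The two compounds have the same atoms, joined differently, so the change is from a tertiary to a secondary amine carrying a branched chain of the same size.

Among the compounds with values here, no measured pair in this set differs only in this way, so the step can only be anticipated. Compound 2 shows that a secondary amine on a related core still reaches a low number, and the change from compound 3 is an arrangement of the same atoms rather than an addition or loss. Compound 4 is therefore expected to stay close to compound 3, with a step of a 1.2-fold lower number from compound 3 to compound 4 (0.09 log units; within the scatter) that lies within the scatter of this assay. The estimate for compound 4 in this assay is 3.5 nM, with a range from 1.2 nM to 11 nM.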

Compound 4, inhibition constant: 4.4 nM
Compound 4: middle estimate off by 1.3-fold (0.10 log units), on the low side; the measured number falls inside the stated range.
By their numbers in this assay, from the lowest: compounds 3 and 4 (each within the scatter of the next); then compound 2; then compound 1.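

In this assay, putting (1-ethylbutyl)amino in place of butyl(ethyl)amino on the aromatic carbon gives a 1.0-fold higher number from compound 3 to compound 4 (0.01 log units; within the scatter), so for this pair, a secondary amine carrying a hydrogen-bond donor and a tertiary amine carrying none cannot be told apart by their numbers. The earlier compounds shown here could not show this: the only secondary amine among them, in compound 2, differs from compound 3 in more than one place, whereas this pair changes the amine alone and keeps the core and aryl group fixed. No measurement in hand explains why the gain of the donor and the move to a branched chain leave these two within the scatter.

The compounds shown leave open whether a primary amine, a longer branched chain or an ether oxygen within the chain would be tolerated on this aromatic carbon. They also leave open whether the same exchange of amines would give so small a step on the core of compound 1 or with its aryl group.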